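A few compounds are considered here, and "the series" means these few. Any claim that something is new, unique, unknown or untested is made for them only; others in the source may bear on it.

Compounds measured so far:
compound 1 `O=C1/C(=C/c2ccccc2)CCC/C1=C\c1ccc(F)cc1`, an assay on isolated protein for inhibition of Alpha glucosidase (Homo sapiens), with stated times of 5 min and 15 min, tested at 50 uM (on this read-out higher numbers stand for more inhibition at the one concentration tested (going by the name of the read-out) and lower numbers for less inhibition), 34%
compound 2 `Cc1ccc(/C=C2\CCC/C(=C\c3ccccc3)C2=O)cc1`, 34.1%

Compound 2 stands highest of the two numbers, though its nearest neighbour compound 1 lies within the scatter; the step of a number 0.1 percentage points higher from compound 1 to compound 2 (within the scatter) carries no signal. Compound 3 `Cc1cccc(/C=C2\CCC/C(=C\c3ccccc3)C2=O)c1` differs from compound 2 by 3-methylphenyl in place of 4-methylphenyl on a double-bonded chain carbon bound to a double-bonded ring carbon. Within the data shown here, no measured step bears on moving the methyl within the ring, and the one step known, from fluoro to methyl, changed nothing beyond the scatter. No step beyond the scatter is therefore expected; the estimate is a number 1.1 percentage points lower from compound 2 to compound 3 (within the scatter). For compound 3 the expected value is 33%, in the range 20% to 46%.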

Compound 3, a percentage reported as inhibition, at one concentration (the size of the read-out at that concentration, not a potency): 47.9%
For compound 3 the middle estimate is 14.9 percentage points below the measured one; the measured number lies above the stated range.
By their numbers in this assay, from the lowest: compounds 1 and 2 (each within the scatter of the next); then compound 3.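

In this assay, 3-methylphenyl in place of 4-methylphenyl on a double-bonded chain carbon gives a number 13.8 percentage points higher from compound 2 to compound 3 (beyond the scatter) with the same atoms, so the methyl's placement on this ring matters, which the fluoro-to-methyl step did not show. 3-methylphenyl in place of 4-fluorophenyl gives a number 13.9 percentage points higher from compound 1 to compound 3 (beyond the scatter) in the same direction. No measurement at hand explains this gain.

From the compounds shown here alone, whether 3-fluorophenyl, an amine or a carboxylic acid at that ring position would keep the gain stays open. A single-concentration percentage also leaves potency open.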